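This account rests on a few compounds, and the source may have more. Where it says the series, first, only, none or still open, it means among the compounds named here.

Of the compounds shown here, two have numbers so far in a functional assay on B16-F10 cells (Mus musculus) for antiproliferative activity, read by MTT assay, with a stated time of 48 h (on this read-out lower numbers stand for stronger inhibition and higher numbers for weaker inhibition), and share the same core. Compound 1 (`COc1ccc(/C=C/C(=O)Nc2cc(-c3ccc(Br)cc3)[nH]n2)cc1`) gives 770 nM and compound 2 (`Cc1ccc(-c2cc(NC(=O)/C=C/c3ccc(C(F)(F)F)cc3)n[nH]2)cc1`) gives 1210 nM in that test. These two values lie within the usual scatter of repeated measurements, so compound 2 stands level with compound 1 on the present evidence.

The next compound is compound 3 (`COc1ccc(/C=C/C(=O)Nc2cc(-c3ccc(C)cc3)[nH]n2)cc1`), which differs from compound 2 in one place. It carries methoxy in place of trifluoromethyl on an aromatic carbon, para to a large group methoxy in place of trifluoromethyl on an aromatic carbon and nothing else changes. Among the compounds with values here, no measured pair shows this single swap on its own, so the expectation has little to lean on. The closeness of compound 1 at 770 nM and compound 2 at 1210 nM gives no hint of a large step. In this assay the swap is therefore expected to cause no step beyond the scatter, with no firm direction. The estimated step is a 1.2-fold lower number from compound 2 to compound 3 (0.08 log units; within the scatter) and it stays within that scatter. Compound 3 is expected at 1000 nM with an estimated range from 400 nM to 2500 nM once it is measured.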

Compound 3, half-maximal inhibitory concentration: 1370 nM
The estimate for compound 3 lay 1.4-fold (0.14 log units) below the measured number, and the stated range covers the measured number.
By their numbers in this assay, from the lowest: compounds 1, 2 and 3 (each within the scatter of the next).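

In this assay, within the data shown here, methoxy in place of trifluoromethyl on the aromatic carbon para to a large group gives a 1.1-fold higher number from compound 2 to compound 3 (0.05 log units; within the scatter), the first reading of this swap on its own; at this position the two groups cannot be told apart, although methoxy brings a hydrogen-bond acceptor and trifluoromethyl brings none. Compound 3 also links to compound 1 through a single change, methyl in place of bromo on an aromatic carbon, which gives a 1.8-fold higher number from compound 1 to compound 3 (0.25 log units; within the scatter), so neither single change shown moves the number beyond the scatter. Nothing measured here offers an explanation for this flat result.

Going by these compounds, whether this position tolerates every kind of group remains open, since an amine, a carboxylic acid or a longer chain such as butoxy on the same aromatic carbon could still produce a clear step. On these data alone, it is also open whether methoxy and trifluoromethyl would remain level with bromo in place of methyl on the other aromatic ring, as each swap has so far been read in only one setting.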